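A fluorine swap on a compound at the assay limit

The compounds below may be only part of what the source reports. "The series", "measured", "known", "first", "only" and "open" are said of these compounds alone.

Results in a functional assay on HFF cells (Homo sapiens) for cytotoxicity; on this read-out higher numbers stand for weaker inhibition and lower numbers for stronger inhibition:
Compound 1 `COc1ccc(S(=O)(=O)NN2C(=S)S/C(=C\c3ccc(Cl)c(Cl)c3)C2O)cc1`: > 100000 nM
Compound 2 `O=S(=O)(NN1C(=S)S/C(=C\c2ccc(Cl)c(Cl)c2)C1O)c1ccc(Cl)cc1`: > 100000 nM
Compound 3 `O=C1/C(=C/c2ccccc2F)SC(=S)N1NS(=O)(=O)c1ccccc1`: > 100000 nM

Each of these entries is a limit and not a number. Compound 3 is therefore known only through its limit of > 100000 nM. The change to compound 4 `O=C1/C(=C/c2ccc(F)c(F)c2F)SC(=S)N1NS(=O)(=O)c1ccccc1` is 2,3,4-trifluorophenyl in place of 2-fluorophenyl on a double-bonded chain carbon bound to a double-bonded ring carbon. For the measured compounds named here, the one measured step, a step that the two limits leave unreadable from compound 1 to compound 2, has no readable size, and it concerns chloro in place of methoxy, not fluorine. The remaining guide is the limit of > 100000 nM in this assay, at which 3 of the 3 values shown sit. The expected step, a number no higher from compound 3 to compound 4 (the limit leaves the size open), is thus none beyond the scatter in this assay, in either direction. The estimated value for compound 4 is 100000 nM, with an expected range of 40000 nM to 250000 nM.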

Compound 4, half-maximal inhibitory concentration: > 100000 nM
Compound 4 ended at the assay's limit; the forecaster's own chance of this, stated with the estimate: 75%; the middle value lies on the limit itself.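

In this assay, for the compounds shown here, compound 3 and compound 4 both give limits and not numbers, so no step between them can be read. Whether 2,3,4-trifluorophenyl in place of 2-fluorophenyl changes the read-out at all stays open, as every result is a limit: the limit of > 100000 nM in this assay, at which 4 of the 4 values shown sit.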